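Carboxy(difluoro)methyl on the nitrogen of compound 2

The compounds below may be only part of what the source reports. "The series", "measured", "known", "first", "only" and "open" are said of these compounds alone.

Of the compounds shown here, two have numbers so far in a functional assay on DU-145 cells (Homo sapiens) for cytotoxicity, read by trypan blue exclusion, with a stated time of 96 h; a higher number here means a weaker inhibitor, a lower number a stronger inhibitor. Compound 1 `COC(=O)CCNc1cc(CS(=O)(=O)/C=C/c2c(OC)cc(OC)cc2OC)ccc1OC` gives 1500 nM, and compound 2 `COc1cc(OC)c(/C=C/S(=O)(=O)Cc2ccc(OC)c(N[C@@H](C)C(=O)O)c2)c(OC)c1` gives 25 nM, the lower of the two numbers.

The next structure is compound 3 `COc1cc(OC)c(/C=C/S(=O)(=O)Cc2ccc(OC)c(NC(F)(F)C(=O)O)c2)c(OC)c1`, which keeps the shared core and changes one group: carboxy(difluoro)methyl in place of 1-carboxyethyl on a nitrogen on an aromatic ring. Going by the values given here, the defined stereocentre of the leaving group has no counterpart in the entering group.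

Among the compounds with values here, one measured step bears on this, and only indirectly: a 60-fold lower number from compound 1 to compound 2 (1.78 log units; beyond the scatter), a large step beyond the scatter, also made at a group on a nitrogen on an aromatic ring. Compound 3 keeps the carboxy group of compound 2, at 25 nM, so a step of that size is not expected here. Within the data shown here, no measured compound carries fluorine in this group, which leaves the expectation loose. In this assay, the expected result is a small shift to a higher number, with a 1.6-fold higher number from compound 2 to compound 3 (0.20 log units; within the scatter) as the estimated step. For compound 3 the estimate is 40 nM, with an expected range of 10 nM to 200 nM.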

Compound 3, half-maximal inhibitory concentration: 150 nM
Compound 3: middle estimate off by 3.8-fold (0.57 log units), on the low side; the range from low to high includes it.
By their numbers in this assay, from the lowest: compound 2; then compound 3; then compound 1.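

In this assay, keeping the carboxy group on the nitrogen on an aromatic ring does not by itself preserve the result: carboxy(difluoro)methyl in place of 1-carboxyethyl gives a 6.0-fold higher number from compound 2 to compound 3 (0.78 log units; beyond the scatter) and so the two acid-bearing groups are not interchangeable at this position. Carboxy(difluoro)methyl in place of 2-(methoxycarbonyl)ethyl gives a 10-fold lower number from compound 1 to compound 3 (1.00 log units; beyond the scatter) and so compound 3 keeps part of the gain seen with compound 2, while the two acid-bearing groups now span a measurable range of their own. No measurement on these compounds accounts for the gap between compound 2 and compound 3.

The compounds shown leave open whether that gap tracks the two fluorines or the absence of the defined stereocentre; a plain carboxymethyl group and the opposite stereoisomer of 1-carboxyethyl would separate the two. Also open, on these data alone, is how much of the difference from compound 1 rests on the free carboxylic acid rather than on the chain, which 1-(methoxycarbonyl)ethyl or a primary amide on the same branched chain would test.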